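This account rests on a few compounds, and the source may have more. Where it says the series, first, only, none or still open, it means among the compounds named here.

Compound 1 `CCn1c(C(=O)N[C@H](C)C(=O)OC)ccc1C(CC)(CC)c1ccc(OCS(=O)(=O)c2ccccc2)c(C)c1` carries a 1-(methoxycarbonyl)ethyl group on the amide-type nitrogen. In a functional assay on PC-3 cells (Homo sapiens) for antiproliferative activity, read by MTT assay, with a stated time of 24 h (on this read-out higher numbers stand for weaker inhibition and lower numbers for stronger inhibition), compound 1 gives only a limit, > 50000 nM. Compound 2 `CCN(CC)CCNC(=O)c1ccc(C(CC)(CC)c2ccc(OCS(=O)(=O)c3ccccc3)c(C)c2)n1CC` gives 7130 nM in this assay, and compound 3 `CCn1c(C(=O)NC(C)(C)CO)ccc1C(CC)(CC)c1ccc(OCS(=O)(=O)c2ccccc2)c(C)c1` gives 9850 nM. Both moves away from compound 1 are beyond the scatter: an at least 7.0-fold lower number from compound 1 to compound 2 (0.84 log units; beyond the scatter) and an at least 5.0-fold lower number from compound 1 to compound 3 (0.70 log units; beyond the scatter); the two replacements sit within the scatter of one another, a 1.4-fold higher number from compound 2 to compound 3 (0.14 log units; within the scatter). Compound 4 `CCn1c(C(=O)NC2(CO)CC2)ccc1C(CC)(CC)c1ccc(OCS(=O)(=O)c2ccccc2)c(C)c1` differs from compound 1 by 1-(hydroxymethyl)cyclopropyl in place of 1-(methoxycarbonyl)ethyl on an amide-type nitrogen. This change resembles the move to compound 3, as both bring in a group carrying hydroxymethyl in place of the ester. The step is therefore expected to be an at least 5.0-fold lower number from compound 1 to compound 4 (0.69 log units; beyond the scatter), a lowering of the same kind. Compound 4 is expected to give 10000 nM in this assay, between 3000 nM and 40000 nM.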

Compound 4, half-maximal inhibitory concentration: 3560 nM
Estimate against measurement, compound 4: 2.8-fold (0.45 log units) above; the range from low to high includes it.
By their numbers in this assay, from the lowest: compounds 4, 2 and 3 (each within the scatter of the next, the first and the last beyond it). At a limit, above all of these: compound 1.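

At the amide-type nitrogen, the two hydroxymethyl-bearing groups are not interchangeable in this assay: 1-(hydroxymethyl)cyclopropyl gives a 2.8-fold lower number from compound 3 to compound 4 (0.44 log units; beyond the scatter), so the hydroxymethyl alone does not set the number. Compound 4 and the 2-(diethylamino)ethyl amide stay level (a 2.0-fold lower number from compound 2 to compound 4 (0.30 log units; within the scatter)), so two quite different groups here give matching numbers. The gain over the ester, an at least 14-fold lower number from compound 1 to compound 4 (1.14 log units; beyond the scatter), is only a lower bound, because compound 1 stands at a limit: the limit of > 50000 nM in this assay, at which 1 of the 4 values shown sits.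

Open, on these data alone, is whether a 1-(hydroxymethyl)cyclobutyl group would continue this trend. Also open, as far as these compounds go, is whether a carboxylic acid could replace the hydroxymethyl.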